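The source may hold more compounds than are shown below. What is called first, only, known or untested is meant among the compounds shown, and "the series" means these compounds.

Measured in an ADME assay on S9 fraction from liver (Rattus norvegicus) for metabolic stability, read by LC-MS, using NADPH, with a stated time of 30 min; a higher number here means that more of the compound is left, a lower number that less of the compound is left:
compound 1, `CCCCCCCCc1ccc(OCC(=O)Cn2nnc(-c3cccnc3)n2)cc1`: 12%.
compound 2, `CCCCCCCCc1ccc(OCC(=O)Cn2nnc(Cc3ccccc3)n2)cc1`: < 5%, a limit of the assay.
compound 3, `CCCCCCCCc1ccc(OCC(=O)Cn2nnnc2C)cc1`: 32%.

Compound 3 stands highest of the two numbers in this assay; the nearest, compound 1, sits clearly lower. Among the measured compounds shown here, compound 4, `CCCCCCCCc1ccc(OCC(=O)Cn2nnnc2C(=O)OC)cc1`, is not yet measured. methoxycarbonyl in place of methyl on an aromatic carbon The only measured step, a number at least 7 percentage points lower from compound 1 to compound 2 (that floor lies within the scatter), alters a different substituent on the shared core and so does not match this change; its floor rests on (the limit of < 5% in this assay, at which 1 of the 3 values shown sits). For the measured compounds named here, no measured step bears directly on the methyl to methoxycarbonyl exchange. A moderate downward step is nonetheless expected, a number 14 percentage points lower from compound 3 to compound 4 (beyond the scatter). Compound 4 is expected to give 18% in this assay, with a range from 5% to 40%.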

Compound 4, percent of the compound remaining: 38%
The estimate for compound 4 lay 20 percentage points below the measured number; the measured number falls inside the stated range.
By their numbers in this assay, from the lowest: compound 1; then compounds 3 and 4 (each within the scatter of the next). At a limit, below all of these: compound 2.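

In this assay, methoxycarbonyl in place of methyl on the aromatic carbon between two ring nitrogen atoms gives a number 6 percentage points higher from compound 3 to compound 4 (within the scatter) as the step. This position therefore takes methoxycarbonyl, with 4 heavy atoms and 2 hydrogen-bond acceptors against 1 heavy atom and 0 hydrogen-bond acceptors for methyl, and the numbers of compound 3 and compound 4 cannot be told apart.

Going by these compounds, whether a carboxylic acid or a primary amide on this same carbon would stay level with compound 4 remains open. Nothing measured here gives a cause for this step.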